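This account rests on a few compounds, and the source may have more. Where it says the series, first, only, none or still open, it means among the compounds named here.

Measured compounds:
Compound 1 `Cc1csc(N/N=C/c2ccccc2)n1`: 1.32 nM
Compound 2 `C(=N/Nc1nc(-c2ccccc2)cs1)\c1ccccc1`: 91.2 nM
Compound 3 `Cc1csc(N/N=C/c2ccc(Cl)cc2Cl)n1`: 17 nM

In an assay on mitochondria for inhibition of Amine oxidase [flavin-containing] B (Bos taurus) (a higher number here means a weaker inhibitor, a lower number a stronger inhibitor), compound 1 gives 1.32 nM, while compound 2 gives 91.2 nM and compound 3 gives 17 nM. Compound 4 `Clc1ccc(/C=N/Nc2nc(-c3ccccc3)cs2)c(Cl)c1` has not yet been measured. The difference between the core of compound 1 and the core of compound 3 is not broken down here. The change that separates compound 2 from compound 1, (phenyl in place of methyl on an aromatic carbon), produced a 69-fold higher number from compound 1 to compound 2 (1.84 log units; beyond the scatter). Compound 4 arises from compound 3 by the same kind of change, (phenyl in place of methyl on an aromatic carbon); the place differs only in that the ring atom two ring bonds away bears a large group rather than a group of 9 heavy atoms. Since the step from compound 1 to compound 2 is large, a comparable upward step is expected for compound 4 in this assay, namely a 47-fold higher number from compound 3 to compound 4 (1.67 log units; beyond the scatter), though the different core makes its size uncertain. Compound 4 is therefore estimated at 800 nM, expected to lie between 200 nM and 4000 nM.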

Compound 4, inhibition constant: 132 nM
Beside the measured number, compound 4's estimate is 6.1-fold (0.78 log units) above it; measured number below the stated range.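

Phenyl in place of methyl on an aromatic carbon gives a 7.8-fold higher number from compound 3 to compound 4 (0.89 log units; beyond the scatter) in this assay. The change raises the number on both cores, but the size of the step does not carry over from one to the other: the same change on two cores in this assay, a 69-fold higher number (1.84 log units; beyond the scatter) from compound 1 to compound 2 and a 7.8-fold higher number (0.89 log units; beyond the scatter) from compound 3 to compound 4, 8.9-fold (0.95 log units) apart, beyond the scatter of two such steps These two pairs show that the direction held while the size shifted with the core, but they do not show which feature of the core sets the size, or how large the step would be on any further core.

The compounds shown leave open whether ethyl or an amine at this place would follow the same course as phenyl. They also leave open how the step would run on a core carrying a single chlorine or a methoxy group.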